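This account rests on a few compounds, and the source may have more. Where it says the series, first, only, none or still open, it means among the compounds named here.

Measured compounds in the series:
Compound 1 `CNC(=O)c1cccc(S(=O)(=O)Oc2ccc(-c3cncn3C3CCN(C(=O)c4ccc(Cl)c(C(F)(F)F)c4)CC3)cc2)c1`; in an assay on HEK293 cells for antagonist activity at P2X purinoceptor 7 (Homo sapiens), read by fluorescence, with a stated time of 2 h (on this read-out lower numbers stand for stronger inhibition and higher numbers for weaker inhibition), compound 1 gives 112 nM.
Compound 2 `CNC(=O)c1cccc(S(=O)(=O)Oc2ccc(-c3cncn3C3CCN(C(=O)c4ccc(S(C)(=O)=O)cc4)CC3)cc2)c1`; in this assay compound 2 gives 202 nM.
Compound 3 `CNC(=O)c1cccc(S(=O)(=O)Oc2ccc(-c3cncn3C3CCN(C(=O)c4ccc([N+](=O)[O-])cc4)CC3)cc2)c1`; in this assay compound 3 gives 62 nM.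

Compound 3 holds the lowest of the three numbers. Its separation from compound 1 is a 1.8-fold lower number from compound 1 to compound 3 (0.26 log units; within the scatter), so the two cannot be ordered; its separation from compound 2 is a 3.3-fold lower number from compound 2 to compound 3 (0.51 log units; beyond the scatter), a modest step beyond the scatter.

Compound 4 `CNC(=O)c1cccc(S(=O)(=O)Oc2ccc(-c3cncn3C3CCN(C(=O)c4ccc(N(C)C)cc4)CC3)cc2)c1` differs from compound 3 by dimethylamino in place of nitro on an aromatic carbon. Within the data shown here, no measured pair exchanges nitro for dimethylamino. Among the measured compounds shown here, the steps that bear on the position are the three exchanges of the group on the carbonyl carbon: a 1.8-fold higher number from compound 1 to compound 2 (0.26 log units; within the scatter), a 1.8-fold lower number from compound 1 to compound 3 (0.26 log units; within the scatter) and a 3.3-fold lower number from compound 2 to compound 3 (0.51 log units; beyond the scatter). Two of these stay within the scatter and the third is only modest, so the whole set of groups tried at this place spans a narrow band in this assay. The expectation for compound 4 is therefore a step of no more than modest size, with the direction uncertain and a slightly higher number somewhat more likely, since compound 3 already sits at the low end of the band. The expected step of a 2.1-fold higher number from compound 3 to compound 4 (0.32 log units; beyond the scatter) reflects this. Compound 4 is estimated to give 130 nM in this assay, with a range from 45 nM to 400 nM.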

Compound 4, half-maximal inhibitory concentration: 25 nM
Estimate against measurement, compound 4: 5.2-fold (0.72 log units) above; measured number outside the range, below it.
By their numbers in this assay, from the lowest: compound 4; then compounds 3, 1 and 2 (each within the scatter of the next, the first and the last beyond it).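

In this assay dimethylamino, on an aromatic carbon para to a large group, gives the lowest number of the four compounds, and each step to it lies beyond the scatter: a 2.5-fold lower number from compound 3 to compound 4 (0.39 log units; beyond the scatter), a 4.5-fold lower number from compound 1 to compound 4 (0.65 log units; beyond the scatter) and an 8.1-fold lower number from compound 2 to compound 4 (0.91 log units; beyond the scatter). The earlier exchanges at this place reached no further than a modest step between nitro and methylsulfonyl, and two of the three stayed within the scatter; the place now shows a wider span, with the largest step in the set running from methylsulfonyl to dimethylamino. Nothing at hand on these compounds accounts for this step.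

From the compounds shown here alone, whether the lower number is particular to dimethylamino stays open: a primary amine, methylamino, methoxy or diethylamino at this place would show how far it extends. Also open, going by these compounds, is whether the same exchange gives a step of similar size when the methylamide or the sulfonate ester of the core is replaced, for example by a carboxylic acid or a sulfonamide.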